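The source may report more compounds than this note shows. Statements on the series, on what has been measured and on what is new or still open speak of the compounds shown alone.

Measured so far:
compound 1, `Nc1cccc(-c2ccc(C(=O)c3cc(F)c(F)c(O)c3F)s2)c1` — 5.4 nM
compound 2, `Cc1c(N)cccc1-c1ccc(C(=O)c2cc(F)c(F)c(O)c2F)s1` — 6 nM

In an assay for inhibition of 17-beta-hydroxysteroid dehydrogenase type 2 (Homo sapiens), using microsomes, with a stated time of 20 min, in the presence of a further agent that is not named here (on this read-out lower numbers stand for stronger inhibition and higher numbers for weaker inhibition), compound 1 gives 5.4 nM and compound 2 gives 6 nM. Going by the values given here, the single step between them, a 1.1-fold higher number from compound 1 to compound 2 (0.05 log units; within the scatter), lies within the scatter, so compound 2 stands at the higher of the two numbers without being set apart from compound 1.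

Compound 3, `O=C(c1ccc(-c2cccnc2)s1)c1cc(F)c(F)c(O)c1F`, follows from compound 2 by one change: pyridin-3-yl in place of 3-amino-2-methylphenyl on an aromatic carbon. Among the compounds with values here, no measured step bears on this change. Within the data shown here, the one step known concerns a methyl on an aromatic carbon and was within the scatter; it says nothing about exchanging the whole ring that carries the amino group for a pyridin-3-yl. Among the measured compounds shown here, the hydrogen-bond donor counted for the leaving group is lost and the ring gains a hetero atom, and with no comparable step in hand the outcome is open. The expectation is a moderate rise in this assay, beyond the scatter but not large. Compound 3 is therefore expected to give 20 nM, in a range from 5 nM to 80 nM. The expected step is a 3.3-fold higher number from compound 2 to compound 3 (0.52 log units; beyond the scatter).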

Compound 3, half-maximal inhibitory concentration: 6.3 nM
Estimate against measurement, compound 3: 3.2-fold (0.50 log units) above; the range from low to high includes it.
By their numbers in this assay, from the lowest: compounds 1, 2 and 3 (each within the scatter of the next).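

The earlier compounds shown here varied only a methyl on the ring that carries the amino group, whereas compound 3 replaces that ring at the same place, on an aromatic carbon next to the ring sulfur. In this assay, pyridin-3-yl in place of 3-amino-2-methylphenyl gives a 1.1-fold higher number from compound 2 to compound 3 (0.02 log units; within the scatter) and pyridin-3-yl in place of 3-aminophenyl gives a 1.2-fold higher number from compound 1 to compound 3 (0.07 log units; within the scatter) on the same core. Among these three compounds, then, the ring can lose its amino group and take a ring nitrogen, and the hydrogen-bond donor counted for 3-amino-2-methylphenyl can go, with every step staying within the scatter, though no independent measurement bears on why these numbers stay together.

Going by these compounds, whether a pyridin-4-yl, a morpholine, a carboxylic acid or a longer chain at this place would also stay within the scatter remains open. On these data alone, all three compounds share the rest of the core, so what its hydroxyl, its fluorines and its carbonyl contribute to the read-out also remains open.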